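Lengthening the Hydroxyalkyl Arm on a Catechol Piperidine

This account rests on a few compounds, and the source may have more. Where it says the series, first, only, none or still open, it means among the compounds named here.

Of the compounds shown here, three have been measured in a functional assay on SK-N-SH cells (Homo sapiens) for inhibition, read by MTT assay, with a stated time of 72 h, tested at 30 uM; on this read-out lower numbers stand for less inhibition of growth and higher numbers for more inhibition of growth at the one concentration tested. Compound 1 `C=CCc1cc(O)c(O)c(CN2CCC(CO)CC2)c1` gives 21.9% and stands highest of the three. Compound 3 `C#CCOc1ccc(CC=C)cc1O` gives 11.8%, a number beyond the scatter below it, and compound 2 `C=CCc1ccc(OCc2cn(-c3ccccc3Cl)nn2)c(O)c1` gives 10.2%, further below still. Compound 4 `C=CCc1cc(O)c(O)c(CN2CCC(CCO)CC2)c1` has not yet been measured. It differs from compound 1 in one place: hydroxymethyl in place of hydroxy on a saturated chain carbon bound to a saturated ring carbon. The group that leaves and the group that enters each carry one hydrogen-bond donor and one hydrogen-bond acceptor, so the step from compound 1 to compound 4 is expected to show no change beyond the scatter in this assay, an estimated a number 0.1 percentage points higher from compound 1 to compound 4 (within the scatter). Compound 4 is therefore estimated at 22%, within a range from 10% to 35%.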

Compound 4, percent growth inhibition at one concentration: 15.3%
The estimate for compound 4 lay 6.7 percentage points above the measured number; the range from low to high includes it.
By their numbers in this assay, from the lowest: compounds 2, 3, 4 and 1 (each within the scatter of the next, the first and the last beyond it).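

With compound 4, the series gains its first comparison of compounds that differ in one place in this assay. On a saturated chain carbon bound to a saturated ring carbon, hydroxymethyl in place of hydroxy gives a number 6.6 percentage points lower from compound 1 to compound 4 (within the scatter) in this measurement, so lengthening the arm from hydroxymethyl to 2-hydroxyethyl is not separated from no change. No accompanying evidence bears on this step.

Going by these compounds, whether a longer chain would separate from compound 1 beyond the scatter remains open. So does the outcome for an amine or a carboxylic acid in place of the hydroxy group.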